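Sulfonamide aryl substituent series: working notes toward compound 4

This account rests on a few compounds, and the source may have more. Where it says the series, first, only, none or still open, it means among the compounds named here.

Measured in an assay on MDA-MB-231 cells for binding affinity to C-X-C chemokine receptor type 4 (Homo sapiens), read by fluorescence and microscopy, with stated times of 10 min and 30 min; on this read-out higher numbers stand for an effect only at larger amounts of compound and lower numbers for an effect already at smaller amounts:
compound 1, `O=C(NCc1ccc(CNS(=O)(=O)c2ccc([N+](=O)[O-])cc2)cc1)c1ccc(F)cc1`: 1000 nM
compound 2, `O=C(NCc1ccc(CNS(=O)(=O)c2ccc(CN3CCCC3)cc2)cc1)c1ccc(F)cc1`: 1 nM
compound 3, `O=C(NCc1ccc(CNS(=O)(=O)c2ccc(Cl)cc2)cc1)c1ccc(F)cc1`: 100 nM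

Compound 3 stands second highest of the three numbers: a 10-fold lower number from compound 1 to compound 3 (1.00 log units; beyond the scatter), and a 100-fold higher number from compound 2 to compound 3 (2.00 log units; beyond the scatter). Compound 4, `O=C(NCc1ccc(CNS(=O)(=O)c2ccc(-c3ccc(F)cc3)cc2)cc1)c1ccc(F)cc1`, differs from compound 3 in one place: 4-fluorophenyl in place of chloro on an aromatic carbon. Among the measured compounds shown here, both measured steps at this aromatic carbon bear on it, one modest (a 10-fold lower number from compound 1 to compound 3 (1.00 log units; beyond the scatter)) and one large (a 100-fold higher number from compound 2 to compound 3 (2.00 log units; beyond the scatter)), so the group at this carbon moves the number widely; the one entering group with more heavy atoms than chloro, (pyrrolidin-1-yl)methyl, gave the lowest number of the three. A lowering beyond the scatter is therefore expected, though smaller than that step. The estimated step is a 3.3-fold lower number from compound 3 to compound 4 (0.52 log units; beyond the scatter). Compound 4 is expected near 30 nM, in the range 5 nM to 300 nM.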

Compound 4, effective concentration (reported as EC, without a stated level of effect): 100 nM
Beside the measured number, compound 4's estimate is 3.3-fold (0.52 log units) below it; the range from low to high includes it.
By their numbers in this assay, from the lowest: compound 2; then compounds 3 and 4 (each within the scatter of the next); then compound 1.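

Heavy-atom count alone does not set the number at this aromatic carbon: 4-fluorophenyl, with its six-membered aromatic ring of carbon only, gives no change at the digits printed from compound 3 to compound 4 (within the scatter) and, against the other large group, a 100-fold higher number from compound 2 to compound 4 (2.00 log units; beyond the scatter) so that (pyrrolidin-1-yl)methyl alone keeps the low number. Against nitro the same group gives a 10-fold lower number from compound 1 to compound 4 (1.00 log units; beyond the scatter) and thus matches the step seen with chloro. No measurement shown here accounts for these differences. Open, on these data alone, is whether the low number of compound 2 goes with the ring amine or with its methylene link; a cyclopentylmethyl group or a directly attached pyrrolidin-1-yl group would separate the two.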